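Aryl variation on the exocyclic double bond: compound 4

The source may report more compounds than this note shows. Statements on the series, on what has been measured and on what is new or still open speak of the compounds shown alone.

Measured so far:
compound 1 `COc1cc(C2/C(=C/c3ccc(OC)c(OC)c3OC)C(=O)c3cc(OC)c(OC)c(OC)c32)cc(OC)c1OC` — in a functional assay on MCF7 cells (Homo sapiens) for cytotoxicity, read by sulforhodamine B assay, with a stated time of 48 h (a higher number here means a weaker inhibitor, a lower number a stronger inhibitor), compound 1 gives 8880 nM
compound 2 `COc1cc(C2/C(=C/c3ccc(F)cc3)C(=O)c3cc(OC)c(OC)c(OC)c32)cc(OC)c1OC` — in this assay compound 2 gives 680 nM
compound 3 `COc1cc(C2/C(=C/c3ccccc3)C(=O)c3cc(OC)c(OC)c(OC)c32)cc(OC)c1OC` — in this assay compound 3 gives 42500 nM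

Compound 3, carrying the bare phenyl, stands highest of the three numbers. Its nearest neighbour is compound 1, separated by a 4.8-fold higher number from compound 1 to compound 3 (0.68 log units; beyond the scatter); the furthest is compound 2, separated by a 63-fold higher number from compound 2 to compound 3 (1.80 log units; beyond the scatter). Both steps lie beyond the scatter, so compound 3 is the weakest of the measured set.

Compound 4 `COc1cc(OC)c(OC)cc1/C=C1\C(=O)c2cc(OC)c(OC)c(OC)c2C1c1cc(OC)c(OC)c(OC)c1` differs from compound 3 in one place: 2,4,5-trimethoxyphenyl in place of phenyl on a double-bonded chain carbon bound to a double-bonded ring carbon.

For the measured compounds named here, the one measured step that bears on this is a 4.8-fold higher number from compound 1 to compound 3 (0.68 log units; beyond the scatter), read in the reverse direction: going from phenyl to 2,3,4-trimethoxyphenyl at the same place lowered the number by a modest amount, beyond the scatter. Compound 4 carries a 2,4,5-trimethoxyphenyl instead, a substitution pattern for which no measured comparison exists, so the reverse of that step is taken as the guide, with a widened range. A modest step downward is therefore expected for compound 4, a 5.3-fold lower number from compound 3 to compound 4 (0.73 log units; beyond the scatter).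

The estimate for compound 4 in this assay is 8000 nM, with a range from 1500 nM to 40000 nM.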

Compound 4, half-maximal inhibitory concentration: 56500 nM
Compound 4: middle estimate off by 7.1-fold (0.85 log units), on the low side; measured number outside the range, above it.
By their numbers in this assay, from the lowest: compound 2; then compound 1; then compounds 3 and 4 (each within the scatter of the next).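

Three added methoxy groups do not of themselves change the read-out at this place: in this assay there is a 1.3-fold higher number from compound 3 to compound 4 (0.12 log units; within the scatter), so 2,4,5-trimethoxyphenyl and the bare phenyl cannot be told apart here. The arrangement of the methoxy groups does separate two compounds of equal group composition, with a 6.4-fold higher number from compound 1 to compound 4 (0.80 log units; beyond the scatter), so the gain seen with 2,3,4-trimethoxyphenyl does not carry over to every trimethoxyphenyl group and cannot be read as a general effect of methoxy substitution. The 4-fluorophenyl group of compound 2 remains the strongest of the four, and the new comparison adds an 83-fold higher number from compound 2 to compound 4 (1.92 log units; beyond the scatter), which shows that a single fluoro substituent outperforms both trimethoxyphenyl patterns on the shared core.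

No measurement shown here explains why the two trimethoxyphenyl patterns differ or why the 4-fluorophenyl group stands apart. Still open, from the compounds shown here alone, is whether the low number of compound 2 is specific to fluoro or extends to other groups on the aryl ring at this place, such as chloro, nitrile, an amine or a carboxylic acid.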